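The source may hold more compounds than are shown below. What is called first, only, known or untested is meant among the compounds shown, and "the series" means these compounds.

Measured compounds in a functional assay on NB-4 cells (Homo sapiens) for inhibition, read by XTT assay, with a stated time of 48 h; a lower number here means a stronger inhibitor, a higher number a weaker inhibitor:
Compound 1 `COc1ccc(C(=O)/C(=C/c2ccc(Cl)cc2Cl)CCOC(C)=O)cc1` gives 34800 nM.
Compound 3 `COc1ccc(C(=O)/C(=C/c2ccc(Cl)cc2)CCOC(C)=O)cc1` gives 36300 nM.
Compound 2 `COc1ccc(C(=O)/C(=C/C2CCCCC2)CCOC(C)=O)cc1` gives only a limit, > 100000 nM.

Compound 1 holds the lower of the two numbers, with compound 3 beside it within the scatter (a 1.0-fold higher number from compound 1 to compound 3 (0.02 log units; within the scatter)). Compound 2 sits at the limit of > 100000 nM in this assay, at which 1 of the 3 values shown sits, and the step of an at least 2.8-fold higher number from compound 1 to compound 2 (0.45 log units; beyond the scatter) is at least modest.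

Compound 4 `COc1ccc(C(=O)/C(=C/c2ccc(Cl)cc2Cl)CC(C)C)cc1` differs from compound 1 by isopropyl in place of acetoxymethyl on a saturated chain carbon bound to a double-bonded chain carbon. Within the data shown here, none of the measured steps touches this saturated chain carbon; all three vary the group on the double-bonded chain carbon. Among the measured compounds shown here, no step therefore bears directly on the change, and compound 4 is expected to stay near compound 1. The expected step is a 1.0-fold higher number from compound 1 to compound 4 (0.00 log units; within the scatter). Compound 4 is estimated at 35000 nM, with a range from 12000 nM to 100000 nM.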

Compound 4, half-maximal inhibitory concentration: 14600 nM
Compound 4: the middle estimate sits 2.4-fold (0.38 log units) above what was measured, and the stated range covers the measured number.
By their numbers in this assay, from the lowest: compound 4; then compounds 1 and 3 (each within the scatter of the next). At a limit, above all of these: compound 2.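

At the saturated chain carbon bound to a double-bonded chain carbon, the change matters in this assay: isopropyl in place of acetoxymethyl gives a 2.4-fold lower number from compound 1 to compound 4 (0.38 log units; beyond the scatter). Among these compounds, the earlier steps all varied the group on the double-bonded chain carbon, so this is the first sign that a second place on the shared core can move the number, and that acetoxymethyl is not required there for inhibition. Nothing shown accounts for this step. From the compounds shown here alone, whether a hydroxyl, an amine, a carboxylic acid or a longer chain at this place would lower the number further remains open. So does whether isopropyl would have the same effect alongside the 4-chlorophenyl group of compound 3.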